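Swapping a trihydroxyphenyl for a bromophenyl on the chain

The source may hold more compounds than are shown below. What is called first, only, known or untested is meant among the compounds shown, and "the series" means these compounds.

Compound 1, `O=C(/C(=C\c1c(O)cc(O)cc1O)S(=O)(=O)c1ccccc1Br)c1ccc(Cl)cc1`, was tested in a functional assay on DU-145 cells (Homo sapiens) for inhibition, read by trypan blue exclusion, with a stated time of 96 h (on this read-out higher numbers stand for weaker inhibition of growth and lower numbers for stronger inhibition of growth), where compound 1 gives 50000 nM. Compound 2, `Cc1ccc(CS(=O)(=O)/C(=C/c2c(O)cc(O)cc2O)C(=O)c2ccc(Cl)cc2)cc1`, differs from it by a 4-methylbenzyl in place of 2-bromophenyl on a sulfonyl sulfur, a step of an at least 2.0-fold higher number from compound 1 to compound 2 (0.30 log units; that floor lies within the scatter). For compound 2 the read-out is only a limit of the assay, > 100000 nM, so where compound 2 truly stands is not known; it sits at the limit of > 100000 nM in this assay, at which 1 of the 2 values shown sits. Compound 3, `Cc1ccc(CS(=O)(=O)/C(=C/c2ccccc2Br)C(=O)c2ccc(Cl)cc2)cc1`, is the next change: 2-bromophenyl in place of 2,4,6-trihydroxyphenyl on a double-bonded chain carbon bound to a double-bonded chain carbon. Among the measured compounds shown here, no measured step touches this place on the double-bonded chain carbon, so the one step in hand, from a group on the sulfonyl sulfur, gives no guide to its direction or size. For the measured compounds named here, the only anchor is compound 2 at the limit. Compound 3 is therefore expected to stay near that level, a change of a number no higher from compound 2 to compound 3 (the limit leaves the size open), and the estimate for compound 3 is 100000 nM, between 30000 nM and 300000 nM, with a real chance that this assay again reports only a limit.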

Compound 3, concentration for 50% growth inhibition: 25000 nM
For compound 3 the middle estimate is 4.0-fold (0.60 log units) above the measured one; measured number outside the range, below it.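

Among the compounds shown here, this is the first step at the double-bonded chain carbon, and it shows that this place affects the result: in this assay, 2-bromophenyl in place of 2,4,6-trihydroxyphenyl gives an at least 4.0-fold lower number from compound 2 to compound 3 (0.60 log units; beyond the scatter). With the 4-methylbenzyl group on the sulfonyl sulfur, inhibition of growth therefore does not depend on the 2,4,6-trihydroxyphenyl group, as compound 3 carries no hydrogen-bond donors in that group's place. The true size of the step is unknown, since compound 2 has only a limit and the step gives only a floor: the limit of > 100000 nM in this assay, at which 1 of the 3 values shown sits.

On these data alone, the swap removes the hydroxyl groups and adds the bromine in one move, so it remains open which of the two matters; a plain phenyl or a 2-methoxyphenyl at this place would help to separate them. As far as these compounds go, it is also open whether the same swap would act alike with a 2-bromophenyl on the sulfonyl sulfur.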